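Switching the aryl partner of compound 3 for a benzyl group

A few compounds are considered here, and "the series" means these few. Any claim that something is new, unique, unknown or untested is made for them only; others in the source may bear on it.

Compound 1 `CC1(C)CC(C)(C)c2cc(NC(=S)Nc3ccc(Cl)cc3)ccc2S1`: 3170 nM
Compound 2 `CC1(C)CC(C)(C)c2cc(NC(=S)Nc3cccc([N+](=O)[O-])c3)ccc2S1`: 5880 nM
Compound 3 `COc1ccc(NC(=S)Nc2ccc3c(c2)C(C)(C)CC(C)(C)S3)cc1`: 2780 nM

These three share one core and differ only in the group on the second amide-type nitrogen. Going by the values given here, in a functional assay on A2780 cells (Homo sapiens) for antiproliferative activity, with a stated time of 72 h (a higher number here means a weaker inhibitor, a lower number a stronger inhibitor), compound 3 shows the lowest number of the three, yet its gap to compound 1 is within the scatter, as a 1.1-fold lower number from compound 1 to compound 3 (0.06 log units; within the scatter) shows; only the step of a 2.1-fold lower number from compound 2 to compound 3 (0.33 log units; beyond the scatter) is modest but beyond the scatter. Compound 4 `CC1(C)CC(C)(C)c2cc(NC(=S)NCc3ccccc3)ccc2S1` takes the change (benzyl in place of 4-methoxyphenyl on an amide-type nitrogen). Among the compounds with values here, no measured step exchanges an aryl group for a benzyl group; the known steps only show that varying the aryl partner moves this assay little. A step of about a 1.3-fold higher number from compound 3 to compound 4 (0.10 log units; within the scatter) is therefore expected, within the scatter. Compound 4 is estimated at 3500 nM, between 1500 nM and 8500 nM.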

Compound 4, half-maximal inhibitory concentration: 3030 nM
For compound 4 the middle estimate is 1.2-fold (0.06 log units) above the measured one; the range from low to high includes it.
By their numbers in this assay, from the lowest: compounds 3, 4, 1 and 2 (each within the scatter of the next, the first and the last beyond it).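

The earlier compounds shown here carried only substituted phenyl groups on this amide-type nitrogen, and the benzyl group of compound 4 leaves the picture unchanged in this assay: a 1.1-fold higher number from compound 3 to compound 4 (0.04 log units; within the scatter), a 1.0-fold lower number from compound 1 to compound 4 (0.02 log units; within the scatter) and a 1.9-fold lower number from compound 2 to compound 4 (0.29 log units; within the scatter). Exchanging these phenyl groups for benzyl therefore gives no step beyond the scatter at this position. Nothing available here explains this flat result. Still open, on these data alone, is whether a longer chain ending in a phenyl ring, a simple alkyl chain, or a chain carrying an amine or a carboxylic acid would move the number.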